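Cyclohexyl in place of 4-methylphenyl at the amide carbonyl

The source may hold more compounds than are shown below. What is called first, only, known or untested is meant among the compounds shown, and "the series" means these compounds.

Three compounds of the series carry numbers in a functional assay on cells for positive allosteric modulation of metabotropic glutamate receptor 5 (Rattus norvegicus), read by calcium flux; a higher number here means that more compound is needed for the effect, a lower number that less compound is needed. Compound 1 `Cc1ccc(C(=O)Nc2cc(-c3ccccc3)nn2-c2ccccc2)cc1` gives 64 nM. Compound 2 `O=C(Nc1cc(-c2ccccc2)nn1-c1ccccc1Cl)c1ccccc1` gives 62 nM, and compound 3 `N#Cc1ccc(C(=O)/N=c2\cc(-c3ccccc3)n(C(=O)c3ccc(C#N)cc3)n2-c2ccccc2)cc1` gives 43 nM. Among the compounds with values here, compound 1 thus sits together with compound 2 and compound 3, all three within the usual scatter of one another, so the numbers so far do not separate them.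

Compound 4 `O=C(Nc1cc(-c2ccccc2)nn1-c1ccccc1)C1CCCCC1` is not yet measured. It differs from compound 1 in one place: cyclohexyl in place of 4-methylphenyl on a carbonyl carbon. Within the data shown here, no pair among the measured compounds covers a change of this kind, so nothing measured tells how large a step it makes.

In this assay the step is expected to be a 2.5-fold higher number from compound 1 to compound 4 (0.40 log units; beyond the scatter), a modest move toward a larger number. On that basis compound 4 is expected to give about 160 nM, with a range from 50 nM to 600 nM to be read as an estimate only.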

Compound 4, half-maximal effective concentration: > 10000 nM
Compound 4: a limit, no number (the forecaster's own chance of this, stated with the estimate: 10%); at least 62-fold (1.79 log units) between middle value and limit.
By their numbers in this assay, from the lowest: compounds 3, 2 and 1 (each within the scatter of the next). At a limit, above all of these: compound 4.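

In this assay compound 4 gives > 10000 nM as a limit of the assay and not a number. Cyclohexyl in place of 4-methylphenyl on a carbonyl carbon makes an at least 150-fold higher number from compound 1 to compound 4 (2.19 log units; beyond the scatter) and is the first single change in the series with a step that can be read. Compounds 1, 2 and 3 all carry a six-membered aromatic ring on this carbonyl and lie within the scatter of one another, so only compound 4 shows that this place does not accept every six-membered carbon ring.

The change swaps the aromatic ring for a non-aromatic one and also removes the methyl, and the compounds shown do not separate these two parts. From the compounds shown here alone, whether a pyridine ring, a cyclopentyl group or an open hexyl chain would be accepted here also stays open.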